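Amino removal on the ethynyl nucleoside core

The source may hold more compounds than are shown below. What is called first, only, known or untested is meant among the compounds shown, and "the series" means these compounds.

Measured in a functional assay on HCT-116 cells (Homo sapiens), read by MTT assay, with a stated time of 72 h; on this read-out higher numbers stand for weaker inhibition and lower numbers for stronger inhibition:
compound 1 `COc1ncnc2c1c(-c1ccsc1)cn2[C@@H]1O[C@H](CO)[C@@H](O)[C@H]1O`: 140 nM
compound 2 `COc1ncnc2c1c(-c1cccs1)cn2[C@@H]1O[C@H](CO)[C@@H](O)[C@H]1O`: 440 nM
compound 3 `C#Cc1cn([C@@H]2O[C@H](CO)[C@@H](O)[C@H]2O)c2nc(N)nc(OC)c12`: > 20000 nM, a limit of the assay and not a number.

Compound 3 thus stands at the limit of > 20000 nM in this assay, at which 1 of the 3 values shown sits, with no number of its own. Compound 4 `C#Cc1cn([C@@H]2O[C@H](CO)[C@@H](O)[C@H]2O)c2ncnc(OC)c12` differs from it by hydrogen in place of amino on an aromatic carbon. Among the measured compounds shown here, the one measured step, a 3.1-fold higher number from compound 1 to compound 2 (0.50 log units; beyond the scatter), concerns the thiophene isomers and does not touch the amino group, so it gives no guide here. For the measured compounds named here, compounds 1 and 2 carry no amino group and both give numbers, but each differs from compound 3 in more than one place, so no single step connects them to compound 4. Compound 4 is therefore expected to move by an at least 20-fold lower number from compound 3 to compound 4 (1.30 log units; beyond the scatter) away from the limit, with low confidence. The estimate for compound 4 is 1000 nM, with a range of 100 nM to 15000 nM.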

Compound 4, half-maximal inhibitory concentration: 5140 nM
The estimate for compound 4 lay 5.1-fold (0.71 log units) below the measured number; the measured number falls inside the stated range.
By their numbers in this assay, from the lowest: compound 1; then compound 2; then compound 4. At a limit, above all of these: compound 3.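

In this assay, hydrogen in place of amino gives the ethynyl compound a measurable number: an at least 3.8-fold lower number from compound 3 to compound 4 (0.59 log units; beyond the scatter). Compound 3 remains a limit of the assay, so the full size of this step cannot be read: the limit of > 20000 nM in this assay, at which 1 of the 4 values shown sits. Without the amino group, ethynyl also emerges as clearly weaker than either thiophene on the same aromatic carbon: a 12-fold higher number from compound 2 to compound 4 (1.07 log units; beyond the scatter), and a 37-fold higher number from compound 1 to compound 4 (1.56 log units; beyond the scatter).

Going by these compounds, whether a methylamino group or a chlorine in place of amino would read like hydrogen stays open. So does the effect of amino on the thiophene compounds.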